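Swapping a Dimethylpiperazine for Piperazine

The source may hold more compounds than are shown below. What is called first, only, known or untested is meant among the compounds shown, and "the series" means these compounds.

- Compound 1 `Cc1cn2cc(-c3cc4ccc(N5CCN(C)[C@@H](C)C5)cc4oc3=O)nc2c(C)n1`: 260 ng.h/mL
- Compound 2 `Cc1cn2cc(-c3cc4ccc(N5CCN(C)CC5)cc4oc3=O)nc2cn1`: < 10 ng.h/mL

Both compounds were tested in an ADME assay on the whole organism (Rattus norvegicus, strain Sprague-Dawley) for pharmacokinetics, with a stated time of 6 h, at a dose of 10 mg/kg by the oral route; a lower number here means less compound in the circulation, a higher number more compound in the circulation at the dose given. Going by the values given here, in this test, compound 1 gives 260 ng.h/mL, the only true number available so far. Compound 2 reads < 10 ng.h/mL, which is a limit of the assay and not a number.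

The next molecule is compound 3 `Cc1cn2cc(-c3cc4ccc(N5CCNCC5)cc4oc3=O)nc2c(C)n1`, which has not yet been measured. It keeps the core of compound 1 but carries piperazin-1-yl in place of 3,4-dimethylpiperazin-1-yl on an aromatic carbon.

Among the compounds with values here, no measured pair of compounds isolates this swap, so any forecast for this assay is loose. The results show that a compound in this small set can give a clear reading, as compound 1 does at 260 ng.h/mL. Compound 2 gives only a limit. A fall somewhat beyond the usual scatter seems the likelier outcome, with a chance of no real change. The expected change is a 2.9-fold lower number from compound 1 to compound 3 (0.46 log units; beyond the scatter). For compound 3, the estimated value is 90 ng.h/mL, with an expected range of 20 ng.h/mL to 350 ng.h/mL.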

Compound 3, area under the concentration-time curve: 340 ng.h/mL
Compound 3: the middle estimate sits 3.8-fold (0.58 log units) below what was measured; measured number inside the range.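

In this assay, putting piperazin-1-yl in place of 3,4-dimethylpiperazin-1-yl on an aromatic carbon gives a 1.3-fold higher number from compound 1 to compound 3 (0.12 log units; within the scatter), so this position accepts the smaller ring, with its added hydrogen-bond donor and without the defined stereocentre, at no real cost in the amount of compound reaching the circulation. Going by these compounds alone, compound 2 reads < 10 ng.h/mL, which is a limit of the assay and not a number, and it differs from compound 3 in more than one place, so no step to it can be read. Nothing measured here explains why the two piperazine groups on this core read alike.

The compounds shown do not separate the two methyl groups, since compound 1 carries both and compound 3 neither, so a piperazine bearing a single methyl group on the core of compound 1 would show whether either one matters alone. On these data alone, it also remains open whether this position accepts a ring of a different kind, such as a morpholine, or an open-chain amine in place of the piperazine ring.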